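Triazole-thiol in place of methylthio-oxadiazole on the shared core

The source may hold more compounds than are shown below. What is called first, only, known or untested is meant among the compounds shown, and "the series" means these compounds.

Measured compounds in a functional assay on the whole organism with Mus musculus as the target, in the maximal electroshock model; on this read-out lower numbers stand for an effect already at smaller amounts and higher numbers for an effect only at larger amounts of compound:
- compound 1, `Fc1ccccc1Oc1ccccc1-c1nnc(S)o1`, gives 43.1 mg/kg.
- compound 2, `CSc1nnc(-c2ccccc2Oc2ccccc2F)o1`, gives only the assay limit > 100 mg/kg.
- compound 3, `Oc1nnc(-c2ccccc2Oc2ccccc2F)o1`, gives only the assay limit > 100 mg/kg.

Compound 2 stands at the limit (the limit of > 100 mg/kg in this assay, at which 2 of the 3 values shown sit), so its place among the numbers cannot be set. Compound 4, `Fc1ccccc1Oc1ccccc1-c1n[nH]c(S)n1`, differs from it by 5-sulfanyl-1H-1,2,4-triazol-3-yl in place of 5-(methylsulfanyl)-1,3,4-oxadiazol-2-yl on an aromatic carbon. The step bearing on this is an at least 2.3-fold higher number from compound 1 to compound 2 (0.36 log units; beyond the scatter), which the new compound reverses by removing the methyl, while also exchanging the ring. In this assay a lower number is therefore expected for compound 4, of a size that the limit on compound 2 leaves uncertain; the change is expected as an at least 1.6-fold lower number from compound 2 to compound 4 (0.22 log units; that floor lies within the scatter). Compound 4 is estimated at 60 mg/kg, with a range from 25 mg/kg to 150 mg/kg.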

Compound 4, dose for half-maximal effect: 92 mg/kg
Estimate against measurement, compound 4: 1.5-fold (0.19 log units) below; low and high end bracket the measured number.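

In this assay, exchanging the ring while keeping the sulfanyl gives a 2.1-fold higher number from compound 1 to compound 4 (0.33 log units; beyond the scatter), so the free sulfanyl alone does not preserve the level of compound 1, and the ring at this position counts as well. Against the two other compounds only floors can be read, an at least 1.0-fold lower number from compound 2 to compound 4 (0.03 log units; that floor lies within the scatter) and an at least 1.0-fold lower number from compound 3 to compound 4 (0.03 log units; that floor lies within the scatter), so no gain over either is shown. Both of those compounds give only a limit: the limit of > 100 mg/kg in this assay, at which 2 of the 4 values shown sit.

From the compounds shown here alone, it remains open whether an amine in place of the sulfanyl on the triazole would hold this level. Also open, going by these compounds, is whether a methyl on the triazole sulfur would raise the number as it does on the oxadiazole.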